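The source may hold more compounds than are shown below. What is called first, only, known or untested is meant among the compounds shown, and "the series" means these compounds.

Of the compounds shown here, two have so far been tested in a functional assay on HT-29 cells (Homo sapiens) for cytotoxicity, read by MTT assay, with a stated time of 72 h; a lower number here means that less compound is tolerated, a higher number that more compound is tolerated. Compound 1, `CCCCOC(=O)Nc1ccc([Se][Se]c2ccc(NC(=O)OCCCC)cc2)cc1`, gives 82400 nM. Compound 2, `CCOC(=O)Nc1ccc([Se]C#N)cc1`, gives 66600 nM, and the two numbers lie within the usual scatter of each other, so the measurements do not separate them. Compound 3, `CCCCCCOC(=O)Nc1ccc([Se]C#N)cc1`, differs from compound 2 in a single place: butyl in place of hydrogen on a saturated chain carbon, two bonds along the chain from an oxygen next to a carbonyl group. For the measured compounds named here, no measured pair shows this change, so there is no step to lean on. The expected step is a 1.5-fold lower number from compound 2 to compound 3 (0.17 log units; within the scatter), a modest shift toward a lower number that may not rise beyond the scatter. For compound 3 the estimate is 45000 nM, between 15000 nM and 120000 nM.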

Compound 3, concentration lethal to 50% of the cells: 69900 nM
Beside the measured number, compound 3's estimate is 1.6-fold (0.19 log units) below it; low and high end bracket the measured number.
By their numbers in this assay, from the lowest: compounds 2, 3 and 1 (each within the scatter of the next).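

Putting butyl in place of hydrogen on this saturated chain carbon, which turns ethyl into hexyl, gives a 1.0-fold higher number from compound 2 to compound 3 (0.02 log units; within the scatter) in this assay. For the compounds shown here, this is the first comparison of compounds that differ in one place, and it shows that this added chain leaves the number within the scatter. So, in this assay, this position accepts butyl on the core of compound 2 without a change the measurements can separate.

On these data alone, whether a longer chain, a phenyl ring or an amine at this position would do the same remains open. No measured evidence bears on why the step is this small.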